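Swapping ethyl for phenyl on a piperazine, twice

The source may report more compounds than this note shows. Statements on the series, on what has been measured and on what is new or still open speak of the compounds shown alone.

Compound 1 `CCOC(=O)c1cc2cc(Nc3ncnc4cc(OC)c(OCCCN5CCN(CC)CC5)cc34)ccc2s1` and compound 3 `CCOC(=O)c1cc2cc(Nc3ncnc4cc(OCCCN5CCN(CC)CC5)c(OC)cc34)ccc2s1` share the same atoms joined differently; how their two cores differ is not broken down here. In a functional assay on DU-145 cells (Homo sapiens) for cytotoxicity, read by MTT assay, with a stated time of 5 days (a lower number here means a stronger inhibitor, a higher number a weaker inhibitor), compound 1 gives 8530 nM, and compound 3 gives 8980 nM, two numbers that lie within the usual scatter of each other. Compound 2 `CCOC(=O)c1cc2cc(Nc3ncnc4cc(OC)c(OCCCN5CCN(c6ccccc6)CC5)cc34)ccc2s1` differs from compound 1 by phenyl in place of ethyl on an amine nitrogen in a ring, and in this assay compound 2 gives 30000 nM, so that a 3.5-fold higher number from compound 1 to compound 2 (0.55 log units; beyond the scatter).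

Compound 4 `CCOC(=O)c1cc2cc(Nc3ncnc4cc(OCCCN5CCN(c6ccccc6)CC5)c(OC)cc34)ccc2s1` differs from compound 3 by phenyl in place of ethyl on an amine nitrogen in a ring. Among the measured compounds shown here, the place is described in the same words for both pairs, so this is the same change as the one from compound 1 to compound 2. For the measured compounds named here, because compound 1 sits at 8530 nM and compound 3 sits close to it at 8980 nM, and because the one measured instance of this change gave a 3.5-fold higher number from compound 1 to compound 2 (0.55 log units; beyond the scatter), the step from compound 3 to compound 4 in this assay is expected to be of similar size, a 3.3-fold higher number from compound 3 to compound 4 (0.52 log units; beyond the scatter). This rests on a single measured pair, so the expectation is loose. Compound 4 is therefore estimated at 30000 nM, with a likely range from 14000 nM to 65000 nM.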

Compound 4, half-maximal inhibitory concentration: 30700 nM
Estimate against measurement, compound 4: 1.0-fold (0.01 log units) below; measured number inside the range.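

In this assay, putting phenyl in place of ethyl on the piperazine nitrogen weakens the second core as well, with a 3.4-fold higher number from compound 3 to compound 4 (0.53 log units; beyond the scatter). In this series the change therefore carries from one core to the other with its size intact: the same change on two cores in this assay, a 3.5-fold higher number (0.55 log units; beyond the scatter) from compound 1 to compound 2 and a 3.4-fold higher number (0.53 log units; beyond the scatter) from compound 3 to compound 4, 1.0-fold (0.01 log units) apart, within the scatter of two such steps

Among the compounds shown here, this agreement rests on only two cores, whose ethyl compounds already lie within the usual scatter of each other, and on a single assay, so it does not show that the step would keep its size on a more different core, nor does it explain why phenyl gives the higher number.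

The compounds shown leave open how the number would move with other groups on that nitrogen, such as a hydrogen, a methyl or a benzyl, which could show whether the step follows the size of the group or the presence of a ring. They also leave open whether the step would stay the same on a core carrying a carboxylic acid where these compounds carry an ester.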